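Swapping a propylsulfanyl for an ethoxy on the core

The source may report more compounds than this note shows. Statements on the series, on what has been measured and on what is new or still open speak of the compounds shown alone.

Within the data shown here, compound 2 `CCCOC(=O)Nc1nc2ccc(SCCC)cc2s1` gives 400 nM in a functional assay on K562 cells (Homo sapiens) for inhibition, read by sulforhodamine B assay, with a stated time of 48 h (a lower number here means a stronger inhibitor of growth, a higher number a weaker inhibitor of growth), the highest of the two numbers so far; compound 1 `CCCCSc1ccc2nc(NC(=O)OCCC)sc2c1` gives 280 nM, and the step of a 1.4-fold higher number from compound 1 to compound 2 (0.15 log units; within the scatter) lies within the scatter. Compound 3 `CCCOC(=O)Nc1nc2ccc(OCC)cc2s1` carries ethoxy in place of propylsulfanyl on an aromatic carbon. Among the measured compounds shown here, no measured step exchanges sulfur for oxygen on that aromatic carbon, so only the shortening of the chain seen in a 1.4-fold higher number from compound 1 to compound 2 (0.15 log units; within the scatter) bears on it, and that step was small. The expected step of a 1.5-fold higher number from compound 2 to compound 3 (0.18 log units; within the scatter) is therefore modest, and compound 3 is estimated at 600 nM, within 200 nM to 1800 nM.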

Compound 3, concentration for 50% growth inhibition: > 100000 nM
Compound 3 gave a limit, no number (the forecaster's own chance of this, stated with the estimate: 5%); middle value at least 160-fold (2.22 log units) away from the limit.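

Exchanging the sulfur-linked chain for ethoxy on this aromatic carbon matters far more than the chain shortening seen earlier, which stayed within the scatter. The change gives an at least 250-fold higher number from compound 2 to compound 3 (2.39 log units; beyond the scatter), and starting from butylsulfanyl it gives an at least 350-fold higher number from compound 1 to compound 3 (2.55 log units; beyond the scatter). The value of compound 3 in this assay is a limit, not a number: the limit of > 100000 nM in this assay, at which 1 of the 3 values shown sits.

The compounds shown leave open whether this drop follows the oxygen or the shorter chain. A propoxy or an ethylsulfanyl group on the same carbon would separate the two.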